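Bromo in place of hydrogen on the phenyl of compound 3

This account rests on a few compounds, and the source may have more. Where it says the series, first, only, none or still open, it means among the compounds named here.

Measured compounds in a functional assay on PC-3 cells (Homo sapiens) for antiproliferative activity, read by MTT assay, with a stated time of 72 h; a higher number here means a weaker inhibitor, a lower number a stronger inhibitor:
compound 1 `O=C(COc1ccc(C(=O)/C=C/c2cccc(Cl)c2)cc1)N[C@H]1CCOC1=O` gives 4990 nM
compound 2 `CC(C)c1ccc(/C=C/C(=O)c2ccc(OCC(=O)N[C@H]3CCOC3=O)cc2)cc1` gives 4660 nM
compound 3 `O=C(COc1ccc(C(=O)/C=C/c2ccccc2)cc1)N[C@H]1CCOC1=O` gives 56800 nM

Compound 3 carries the unsubstituted phenyl on the chain and stands at the highest number of the three. Both of its neighbours lie well apart from it: an 11-fold higher number from compound 1 to compound 3 (1.06 log units; beyond the scatter) and a 12-fold higher number from compound 2 to compound 3 (1.09 log units; beyond the scatter) are each large and beyond the scatter. Compound 1 and compound 2 sit within the scatter of each other, as a 1.1-fold lower number from compound 1 to compound 2 (0.03 log units; within the scatter) shows, so the two substituted phenyls cannot be ordered against one another.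

Compound 4 `O=C(COc1ccc(C(=O)/C=C/c2ccc(Br)cc2)cc1)N[C@H]1CCOC1=O` differs from compound 3 by bromo in place of hydrogen on an aromatic carbon. Among the measured compounds shown here, the steps that bear on it are the two removals of a substituent from the phenyl, an 11-fold higher number from compound 1 to compound 3 (1.06 log units; beyond the scatter) and a 12-fold higher number from compound 2 to compound 3 (1.09 log units; beyond the scatter), read in reverse: putting a substituent back onto the phenyl, in either place tried, lowered the number by a large amount. A single bromo on the same phenyl is expected to behave alike, so a large step downward in this assay is expected, a 10-fold lower number from compound 3 to compound 4 (1.01 log units; beyond the scatter), bringing compound 4 close to compound 1 and compound 2. The estimate for compound 4 is 5500 nM, with a range from 2000 nM to 15000 nM.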

Compound 4, half-maximal inhibitory concentration: > 64000 nM
Compound 4 ended at the assay's limit; the forecaster's own chance of this, stated with the estimate: 5%; middle value at least 11-fold (1.06 log units) away from the limit.
By their numbers in this assay, from the lowest: compounds 2 and 1 (each within the scatter of the next); then compound 3. At a limit, above all of these: compound 4.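

In this assay compound 4 gives > 64000 nM, which is a limit of the assay and not a number: the limit of > 64000 nM in this assay, at which 1 of the 4 values shown sits. Compounds 1 and 2 suggested that a substituent on this phenyl lowers the number, but compound 4 goes against that reading: the step of an at least 1.1-fold higher number from compound 3 to compound 4 (0.05 log units; that floor lies within the scatter) gives a floor only, and it shows no lowering from bromo in place of hydrogen. Substitution on this phenyl therefore does not carry the gain by itself, since the 4-bromophenyl stands well apart from the 4-isopropylphenyl in the step of an at least 13-fold higher number from compound 2 to compound 4 (1.13 log units; beyond the scatter) and from the 3-chlorophenyl in the step of an at least 12-fold higher number from compound 1 to compound 4 (1.10 log units; beyond the scatter).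

From the compounds shown here alone, the size of the step between compound 3 and compound 4 stays open, as its floor lies within the scatter and the limit gives no number for compound 4. Also open, going by these compounds, is whether the contrast follows the group itself or, against compound 1, its place on the ring, and how an amine or a methoxy group on the same phenyl would fall relative to these compounds.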